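The source may hold more compounds than are shown below. What is called first, only, known or untested is meant among the compounds shown, and "the series" means these compounds.

Compound 1 `Cc1ccc(NC(=S)NC(=O)c2ccc(OCc3ccc(Cl)cc3Cl)cc2)cc1-c1nc2ccccc2[nH]1` and compound 2 `O=C(NC(=S)Nc1ccc(Cl)c(-c2nc3ccccc3[nH]2)c1)c1ccc(OCc2ccc(Cl)cc2Cl)cc1` share one core, and in a functional assay on HT-29 cells (Homo sapiens) for inhibition, read by MTT assay, with a stated time of 48 h (a lower number here means a stronger inhibitor, a higher number a weaker inhibitor), compound 1 gives 11600 nM, while compound 2 gives 6080 nM. The change between them is chloro in place of methyl on an aromatic carbon and it made a step of a 1.9-fold lower number from compound 1 to compound 2 (0.28 log units; within the scatter). Compound 3 `Cc1ccc(NC(=O)NC(=O)c2ccc(OCc3ccccc3F)cc2)cc1-c1nc2ccccc2[nH]1` is built on a different core, and the difference between the two cores is not broken down here; in this assay compound 3 gives 760 nM, the lowest of the three measured numbers. Compound 4 `O=C(NC(=O)c1ccc(OCc2ccccc2F)cc1)Nc1ccc(Cl)c(-c2nc3ccccc3[nH]2)c1` has not yet been measured. It differs from compound 3 by chloro in place of methyl on an aromatic carbon, the same change already seen in the first pair: in both cases the replacement sits on an aromatic carbon of a six-membered aromatic ring of carbon only, ortho to a 1H-benzimidazol-2-yl group and para to a large group. Because the earlier step of a 1.9-fold lower number from compound 1 to compound 2 (0.28 log units; within the scatter) stayed within the usual scatter, a step of similar, modest size is expected here as well, a 1.5-fold lower number from compound 3 to compound 4 (0.18 log units; within the scatter). Compound 4 is accordingly estimated at 500 nM, with a likely range from 200 nM to 1500 nM.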

Compound 4, half-maximal inhibitory concentration: 590 nM
Compound 4: middle estimate off by 1.2-fold (0.07 log units), on the low side; measured number inside the range.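

Putting chloro in place of methyl on this second core gave a 1.3-fold lower number from compound 3 to compound 4 (0.11 log units; within the scatter) in this assay and so, as on the first core, left the number within the usual scatter. The two steps also agree with each other, which means the swap carried across these two cores without any visible difference in its size: the same change on two cores in this assay, a 1.9-fold lower number (0.28 log units; within the scatter) from compound 1 to compound 2 and a 1.3-fold lower number (0.11 log units; within the scatter) from compound 3 to compound 4, 1.5-fold (0.17 log units) apart, within the scatter of two such steps. For the compounds shown here, this supports treating the swap as a small change in this assay for these two cores, but it rests on only two pairs, and neither step is large enough to show that chloro and methyl truly differ here or to explain why the numbers stay so close.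

Among the compounds shown, this place on the ring carries only methyl or chloro, so the outcome with a fluoro, methoxy or trifluoromethyl group there remains open. Going by these compounds, whether the swap would behave the same way on any core beyond these two also remains open.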